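A few compounds are considered here, and "the series" means these few. Any claim that something is new, unique, unknown or untested is made for them only; others in the source may bear on it.

Compound 1, `CC(C)N(Cc1cccc(OCCCCCC(=O)O)c1)C(=O)c1ccc(-c2cccc3ccccc23)cc1`: > 26000 nM
Compound 2, `CC(C)Oc1cccc(-c2ccc(C(=O)N(Cc3cccc(OCCCCCC(=O)O)c3)C(C)C)cc2)c1`: > 26000 nM

In an ADME assay on HepG2 cells (Homo sapiens) for cytotoxicity, read by CellTiter-Glo and resazurin assay, with a stated time of 72 h (on this read-out higher numbers stand for an effect only at larger amounts of compound and lower numbers for an effect already at smaller amounts), compound 1 gives > 26000 nM; this is a limit of the assay and not a number. Compound 2 likewise gives > 26000 nM in this assay, again a limit rather than a number. The step that the two limits leave unreadable from compound 1 to compound 2 therefore cannot be read in size, since the limit of > 26000 nM in this assay, at which 2 of the 2 values shown sit, shows that both values sit at that same limit. Compound 1 thus stands only at a limit in this assay, with no number above or below it to place it against.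

Compound 3, `COc1cc(OC)cc(-c2ccc(C(=O)N(Cc3cccc(OCCCCCC(=O)O)c3)C(C)C)cc2)c1`, has not yet been measured in this assay. The change from compound 1 is 3,5-dimethoxyphenyl in place of naphthalen-1-yl on an aromatic carbon. Going by the values given here, the one measured step that bears on it, a step that the two limits leave unreadable from compound 1 to compound 2, exchanges the same naphthalen-1-yl group at the same place for another aromatic ring, and its size is unreadable. With compound 1 only at a limit and no readable step to draw on, the step that the limit leaves unreadable from compound 1 to compound 3 is expected to be none beyond the scatter. Compound 3 is therefore estimated at 40000 nM, with a range from 20000 nM to 100000 nM, most likely reported as a limit.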

Compound 3, half-maximal effective concentration: > 26000 nM
Compound 3 ended at the assay's limit (the forecaster's own chance of this, stated with the estimate: 85%); the middle value is on the limit's open side.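

Compound 3 sits at a limit in this assay, as do compound 1 and compound 2, so no step among these three compounds can be read: the limit of > 26000 nM in this assay, at which 3 of the 3 values shown sit. The compounds shown leave open at what concentration any of the three would reach a half-maximal effect, and whether the naphthalen-1-yl, 3-isopropoxyphenyl and 3,5-dimethoxyphenyl groups differ at all.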